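Removing One Methyl on Two Closely Related Cores

The compounds below may be only part of what the source reports. "The series", "measured", "known", "first", "only" and "open" are said of these compounds alone.

Of the compounds shown here, three have so far been measured in a functional assay on OVCAR-3 cells (Homo sapiens); on this read-out higher numbers stand for weaker inhibition of growth and lower numbers for stronger inhibition of growth. Compound 1 `COc1ccccc1-c1cc(O)c2cccnc2n1` gives 47900 nM. Compound 2 `COc1cccc(-c2cc(O)c3c(C)ccnc3n2)c1` gives 25.7 nM, the lowest number of the three. Compound 3 `COc1ccccc1-c1cc(O)c2c(C)ccnc2n1` gives 12900 nM. Compound 2 and compound 3 are built from the same atoms joined differently; the difference between the two cores is not broken down here. Between compound 3 and compound 1 the change is hydrogen in place of methyl on an aromatic carbon, and it produced a 3.7-fold higher number from compound 3 to compound 1 (0.57 log units; beyond the scatter). Compound 4 `COc1cccc(-c2cc(O)c3cccnc3n2)c1` is not yet measured; it arises from compound 2 by the same change, (hydrogen in place of methyl on an aromatic carbon), at a place described in identical words. A step of similar size is expected for this unmeasured pair, a 3.7-fold higher number from compound 2 to compound 4 (0.57 log units; beyond the scatter), because the earlier one was a 3.7-fold higher number from compound 3 to compound 1 (0.57 log units; beyond the scatter). Compound 4 is therefore estimated at 95 nM, most likely between 30 nM and 400 nM.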

Compound 4, concentration for 50% growth inhibition: 55 nM
Compound 4: middle estimate off by 1.7-fold (0.24 log units), on the high side; the measured number falls inside the stated range.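

Replacing methyl with hydrogen on the aromatic carbon opposite the ring nitrogen again raised the number in this assay, with a 2.1-fold higher number from compound 2 to compound 4 (0.33 log units; beyond the scatter). Set beside the earlier step, the change carried over from one core to the other in direction and, within the scatter, in size: the same change on two cores in this assay, a 3.7-fold higher number (0.57 log units; beyond the scatter) from compound 3 to compound 1 and a 2.1-fold higher number (0.33 log units; beyond the scatter) from compound 2 to compound 4, 1.7-fold (0.24 log units) apart, within the scatter of two such steps. Among the compounds shown here, this rests on only two pairs in a single assay, so it does not show what the change would do on any other core.

The compounds shown leave open what a group other than methyl or hydrogen, such as an amine or a longer chain, would do on that aromatic carbon. They also leave open whether a carboxylic acid there would be tolerated on either core.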